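The compounds below may be only part of what the source reports. "The series", "measured", "known", "first", "only" and "open" are said of these compounds alone.

The study concerns a small set of compounds built on a shared core. Compound 1 `COc1ccc(-c2c(Cl)c(=O)c3c(OC)cc(OC)cc3n2S(=O)(=O)c2ccc(OC)cc2)cc1` was not tested in a functional assay on HepG2 cells (Homo sapiens) for antiproliferative activity, with a stated time of 72 h (on this read-out higher numbers stand for an effect only at larger amounts of compound and lower numbers for an effect already at smaller amounts), where the entry for compound 1 reads "not determined" (no result reported), and no result is reported for it there. Compound 2 `COC(=O)c1cc(=O)c2c(OC)cc(OC)cc2[nH]1` reaches only a limit of the assay: in this assay compound 2 gives > 34400 nM. Compound 3 `COc1ccc(-c2cc(=O)c3c(OC)cc(OC)cc3n2S(=O)(=O)c2ccc([N+](=O)[O-])cc2)cc1` likewise reaches only a limit: in this assay compound 3 gives > 29300 nM. Where compound 3 stands, then, is at a limit rather than at a number; of the three entries shown, one further value is also a limit (the limit of > 34400 nM in this assay, at which 1 of the 3 values shown sits) and one carries no number at all, so no step between measured compounds can be drawn from them.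

The next compound, compound 4 `COc1ccc(-c2cc(=O)c3c(OC)cc(OC)cc3n2S(=O)(=O)Cc2ccccc2)cc1`, differs from compound 3 in one place: benzyl in place of 4-nitrophenyl on a sulfonyl sulfur. For the measured compounds named here, since compound 3 sits at the limit (the limit of > 29300 nM in this assay, at which 1 of the 3 values shown sits), no measured step is available to guide the expectation for this change. The step expected a step that the limit leaves unreadable from compound 3 to compound 4 is therefore none beyond the scatter, and the most likely outcome for compound 4 is once again a limit rather than a number. Compound 4 is estimated at 30000 nM in this assay, within a range from 10000 nM to 100000 nM.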

Compound 4, half-maximal effective concentration: > 34400 nM
Compound 4 gave a limit, no number; the forecaster's own chance of this, stated with the estimate: 75%; middle value at least 1.1-fold (0.05 log units) from the limit.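

For the compounds shown here, compound 3 and compound 4 each reach only a limit in this assay, not a number, so no step between them can be read. The compounds shown leave open whether benzyl in place of 4-nitrophenyl on a sulfonyl sulfur changes the result at all, and at what concentration any of them would show an effect in this assay.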